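The compounds below may be only part of what the source reports. "The series", "measured", "known", "first", "only" and "open" are said of these compounds alone.

Compound 1, with the structure `CCCC(C)Oc1cccc2ccc(N)nc12`, stands lowest of the two numbers in an assay on cells with melanin-concentrating hormone receptor 1 (Homo sapiens) as the target, read by radioligand binding (on this read-out higher numbers stand for weaker inhibition and lower numbers for stronger inhibition), where compound 1 gives 105 nM. Within the data shown here, its only measured neighbour is compound 2, with the structure `CC(COC(C)(C)C)Oc1cccc2ccc(N)nc12`, which in this assay gives 306 nM; that pair shows a 2.9-fold higher number from compound 1 to compound 2 (0.46 log units; beyond the scatter). Compound 3, with the structure `CCCOc1cccc2ccc(N)nc12`, has not yet been measured in this assay. It differs from compound 1 by propyl in place of 1-methylbutyl on an oxygen on an aromatic ring. Among the measured compounds shown here, the single measured step bears on it only loosely, as it changed the chain two bonds from the oxygen rather than at the oxygen itself, yet it shows that altering this chain can shift the number beyond the scatter. Compound 3 is therefore expected to sit somewhat higher than compound 1, with a 2.4-fold higher number from compound 1 to compound 3 (0.38 log units; beyond the scatter) as the expected step. Compound 3 is estimated at 250 nM, in a range from 80 nM to 800 nM.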

Compound 3, half-maximal inhibitory concentration: 1100 nM
Compound 3: middle estimate off by 4.4-fold (0.64 log units), on the low side; measured number outside the range, above it.
By their numbers in this assay, from the lowest: compound 1; then compound 2; then compound 3.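

Among these compounds, at this position, on an oxygen on an aromatic ring, the assay responds far more strongly than the earlier compounds showed: this assay gives a 10-fold higher number from compound 1 to compound 3 (1.02 log units; beyond the scatter) for propyl in place of 1-methylbutyl, whereas the only earlier change, tert-butoxy in place of ethyl further along the chain, gave a 2.9-fold higher number from compound 1 to compound 2 (0.46 log units; beyond the scatter) for a smaller shift. Neither 1-methylbutyl nor propyl has a ring, a hydrogen-bond donor or acceptor, or a net charge, so a change between two all-carbon groups is enough to produce a large step here. Nothing available explains the size of this step.

Propyl differs from 1-methylbutyl in both chain length and branching, and this pair cannot separate the two. A straight pentyl chain or a 1-methylethyl group on the same oxygen would bear on that question, while a cyclopentyl group or an amine on the chain remains an open case.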